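From hydroxymethyl to 1-hydroxy-1-methylethyl on one side chain

The compounds below may be only part of what the source reports. "The series", "measured", "known", "first", "only" and "open" are said of these compounds alone.

Measured in a functional assay on K562 cells (Homo sapiens) for cytotoxicity, read by fluorescence, with a stated time of 72 h (a lower number here means a stronger inhibitor, a higher number a weaker inhibitor), so far:
- compound 1 `CSc1nc(NCc2ccc(-c3ccccn3)cc2)c2[nH]nc(C(C)C)c2n1` gives 778 nM
- compound 2 `CC(C)c1n[nH]c2c(NCc3ccc(-c4ccccn4)cc3)nc(S(C)(=O)=O)nc12` gives 640 nM
- compound 3 `CC(C)c1n[nH]c2c(NCc3ccc(-c4ccccn4)cc3)nc(NCCO)nc12` gives 38 nM

Compound 3 has the lowest number of the three, which makes it the strongest inhibitor here. The measured 20-fold lower number from compound 1 to compound 3 (1.31 log units; beyond the scatter) and a 17-fold lower number from compound 2 to compound 3 (1.23 log units; beyond the scatter) are both large, whereas a 1.2-fold lower number from compound 1 to compound 2 (0.08 log units; within the scatter) stays within the scatter.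

Compound 4 `CC(C)c1n[nH]c2c(NCc3ccc(-c4ccccn4)cc3)nc(NCC(C)(C)O)nc12` differs from compound 3 in one group, with 1-hydroxy-1-methylethyl in place of hydroxymethyl on a saturated chain carbon bound to a nitrogen on an aromatic ring. Both large steps brought in the whole (2-hydroxyethyl)amino group, so they show that the group on that aromatic carbon can move the number a long way. Going by the values given here, neither alters the chain once it is there, and no measured compound tests the new group. The data give no direction, so the expectation starts from compound 3 at 38 nM and no step beyond the scatter is expected in this assay. The estimated change is a 1.1-fold higher number from compound 3 to compound 4 (0.02 log units; within the scatter) and this stays an expectation. For compound 4 the estimated value is 40 nM with an expected range from 15 nM to 110 nM until it is measured.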

Compound 4, half-maximal inhibitory concentration: 29 nM
The estimate for compound 4 lay 1.4-fold (0.14 log units) above the measured number, within the range that was stated.
By their numbers in this assay, from the lowest: compounds 4 and 3 (each within the scatter of the next); then compounds 2 and 1 (each within the scatter of the next).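

In this assay, replacing 2-hydroxyethyl with 2-hydroxy-2-methylpropyl gives a 1.3-fold lower number from compound 3 to compound 4 (0.12 log units; within the scatter), so this side chain can carry the larger 2-hydroxy-2-methylpropyl group with no change beyond the scatter. Going by these compounds alone, the large difference from the earlier groups on the aromatic carbon also holds with the new chain, which shows a 22-fold lower number from compound 2 to compound 4 (1.34 log units; beyond the scatter) and a 27-fold lower number from compound 1 to compound 4 (1.43 log units; beyond the scatter), so that difference is not confined to the single chain in compound 3. Nothing measured here explains these numbers.

Both chains end in a hydroxyl group, so the compounds shown leave open how much the number depends on that hydroxyl rather than on the chain that carries it. A chain ending in a methoxy group, an amine or a carboxylic acid would address this, and a longer chain would show how much further this position can be extended.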